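The source may report more compounds than this note shows. Statements on the series, on what has been measured and on what is new or still open speak of the compounds shown alone.

Compound 2 `CCCn1c(=O)c2nc(C(C3CC3)C3CC3)[nH]c2n(CCC)c1=O` carries a dicyclopropylmethyl group on its core. In an assay on cell membranes for binding affinity to adenosine receptor A1 (Cavia porcellus) (a lower number here means a stronger inhibitor, a higher number a weaker inhibitor), compound 2 gives 3 nM, the lowest of the two numbers measured here. Its nearest neighbour, compound 1 `CCCC(CCC)c1nc2c(=O)n(CCC)c(=O)n(CCC)c2[nH]1`, bears 1-propylbutyl at the same position and gives 78 nM in this assay; the step of a 26-fold lower number from compound 1 to compound 2 (1.41 log units; beyond the scatter) is large. Compound 3 `CCCn1c(=O)c2nc(C(c3ccc(F)cc3)C3CC3)[nH]c2n(CCC)c1=O` differs from compound 2 by 4-fluorophenyl in place of cyclopropyl on a saturated chain carbon bound to an aromatic carbon and a saturated ring carbon. Within the data shown here, no measured pair mirrors this exchange; the only step known, from 1-propylbutyl to dicyclopropylmethyl, shows that this position tolerates sizeable change in the number, so a step beyond the scatter in this assay is plausible for compound 3, but its direction cannot be read from compound 1 and compound 2 alone. Compound 3 is therefore expected near its neighbour, with a wide range, at 6 nM between 1 nM and 40 nM, a step of a 2.0-fold higher number from compound 2 to compound 3 (0.30 log units; within the scatter).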

Compound 3, inhibition constant: 250 nM
Beside the measured number, compound 3's estimate is 42-fold (1.62 log units) below it; measured number outside the range, above it.
By their numbers in this assay, from the lowest: compound 2; then compound 1; then compound 3.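

In this assay the step is an 83-fold higher number from compound 2 to compound 3 (1.92 log units; beyond the scatter): the same position that gave a large fall in the number from 1-propylbutyl to dicyclopropylmethyl also gives a large rise, so the number at this carbon can move in either direction. Keeping one cyclopropyl does not preserve the low number of compound 2 once the other gives way to 4-fluorophenyl, which brings a six-membered aromatic ring and 7 heavy atoms in place of a three-membered ring and 3. Nothing measured here accounts for this rise.

The compounds shown cannot separate the contribution of the aromatic ring from that of its fluorine. From the compounds shown here alone, what a plain phenyl, or an isopropyl of intermediate size, would give at this carbon stays open.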